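A Second Benzyloxy Group on Compound 2

The source may report more compounds than this note shows. Statements on the series, on what has been measured and on what is new or still open speak of the compounds shown alone.

Measured so far in a functional assay on KB cells (Homo sapiens) for cytotoxicity, read by MTT assay, with a stated time of 72 h; on this read-out lower numbers stand for stronger inhibition and higher numbers for weaker inhibition:
- compound 1 `O=C(O)/C(=C/c1c[nH]c2ccc(OCc3ccccc3)cc12)c1ccccc1` gives 55500 nM
- compound 2 `CC(=O)n1cc(/C=C(/C(=O)O)c2ccccc2)c2cc(OCc3ccccc3)ccc21` gives 55500 nM
- compound 3 `COc1cccc(/C(=C\c2cn(C(C)=O)c3ccc(OCc4ccccc4)cc23)C(=O)O)c1` gives > 100000 nM, which is a limit of the assay rather than a number

Compound 2 stands level with compound 1 at the digits shown, and the step of no change at the digits printed from compound 1 to compound 2 (within the scatter) changes nothing beyond the scatter. Going by the values given here, the only other measured step is an at least 1.8-fold higher number from compound 2 to compound 3 (0.25 log units; that floor lies within the scatter). On these data alone, its end point, compound 3, sits at the limit (the limit of > 100000 nM in this assay, at which 1 of the 3 values shown sits), so the true size of that step is unknown; it may be much larger than the floor quoted.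

Compound 4 `CC(=O)n1cc(/C=C(/C(=O)O)c2ccc(OCc3ccccc3)cc2)c2cc(OCc3ccccc3)ccc21` differs from compound 2 by benzyloxy in place of hydrogen on an aromatic carbon, placed on an aromatic carbon of a six-membered aromatic ring of carbon only, para to a large group. Among the compounds with values here, the step to compound 3 is the one measurement that bears on this change, since it also adds a group on an aromatic carbon, and it ran toward weaker inhibition as far as the assay could follow. A weakening step in this assay is therefore expected, with a fair chance that only a limit is reported again. Compound 4 is estimated to give about 100000 nM, within a range from 40000 nM to 300000 nM. That estimate means an expected step of a 1.8-fold higher number from compound 2 to compound 4 (0.26 log units; within the scatter).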

Compound 4, half-maximal inhibitory concentration: 43000 nM
The estimate for compound 4 lay 2.3-fold (0.37 log units) above the measured number; measured number inside the range.
By their numbers in this assay, from the lowest: compounds 4, 1 and 2 (each within the scatter of the next). At a limit, above all of these: compound 3.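

In this assay, a 1.3-fold lower number from compound 2 to compound 4 (0.11 log units; within the scatter), so a benzyloxy group on an aromatic carbon of this six-membered ring, para to a large group, leaves the number within the scatter of compound 2. Going by these compounds alone, until now, the only step that added a group to an aromatic carbon of compound 2 ended at a limit, and compound 4 shows that such an addition need not end there, even when the group brings a whole extra aromatic ring. The value of compound 4 is a real number, so this step has a known size, while the step to compound 3 has only a floor: the limit of > 100000 nM in this assay, at which 1 of the 4 values shown sits.

On these data alone, what stays open is whether this position accepts every kind of group equally, since a single substituent cannot show that, and an amine, a carboxylic acid or a longer chain at this place might give a quite different number. The compounds shown also leave open whether any change at this position can bring the number clearly below that of compound 2, and they offer no explanation for the result.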